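A Thiophene Carbonyl in Place of a Morpholine Carbonyl

The compounds below may be only part of what the source reports. "The series", "measured", "known", "first", "only" and "open" are said of these compounds alone.

compound 1 `CCCCC(=O)NC(=S)Nc1nc2cc([N+](=O)[O-])ccc2s1` — "not determined" (no result reported)
compound 2 `O=C(NC(=S)Nc1nc2cc(Br)ccc2s1)N1CCOCC1` — 38900 nM
compound 3 `O=C(NC(=S)Nc1nc2cc([N+](=O)[O-])ccc2s1)N1CCOCC1` — 54800 nM

Three compounds of the shared core are known here. In a functional assay on HeLa cells (Homo sapiens) for cytotoxicity, read by MTT assay, with a stated time of 24 h (on this read-out lower numbers stand for stronger inhibition and higher numbers for weaker inhibition), compound 2 gives 38900 nM, and compound 3 gives 54800 nM. For compound 1 this assay gives "not determined" (no result reported). Among the compounds with values here, the one step between measured compounds, a 1.4-fold higher number from compound 2 to compound 3 (0.15 log units; within the scatter), is the only comparison available, and it sits within the scatter. Compound 3 therefore stands at the higher of the two numbers, but not separated from compound 2 by more than the scatter.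

Compound 4 `O=C(NC(=S)Nc1nc2cc([N+](=O)[O-])ccc2s1)c1cccs1` differs from compound 3 in one place: thiophen-2-yl in place of morpholin-4-yl on a carbonyl carbon. Within the data shown here, no measured step touches this part of the molecule; the only step known concerns the aromatic carbon, not the carbonyl carbon, so it offers no guidance on the direction or the size of this change. The account therefore expects no step beyond the scatter, while allowing a broad range on either side.

Compound 4 is estimated at 50000 nM, with a range from 15000 nM to 160000 nM; the expected step is a 1.1-fold lower number from compound 3 to compound 4 (0.04 log units; within the scatter).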

Compound 4, half-maximal inhibitory concentration: 72600 nM
Compound 4: the middle estimate sits 1.5-fold (0.16 log units) below what was measured; measured number inside the range.
By their numbers in this assay, from the lowest: compounds 2, 3 and 4 (each within the scatter of the next).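

At the carbonyl carbon, thiophen-2-yl in place of morpholin-4-yl gives, in this assay, a 1.3-fold higher number from compound 3 to compound 4 (0.12 log units; within the scatter), and this is the only step shown that touches this position. The exchange swaps a six-membered non-aromatic ring with 2 hetero atoms for a five-membered aromatic ring with 1 hetero atom. The printed step for this single pair does not leave the scatter. The earlier step concerned only the aromatic carbon, and nothing available explains the reading at the carbonyl carbon.

The compounds shown leave open whether other groups on this carbonyl carbon, such as phenyl, piperidin-1-yl or dimethylamino, would give a step beyond the scatter, or whether a longer chain such as pentyl would do so. They also leave open whether thiophen-2-yl would give a similar reading on the bromo-bearing counterpart, compound 2, where the same carbonyl carbon carries morpholin-4-yl.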